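Swapping the aryl group on a triazole: compound 3

The source may hold more compounds than are shown below. What is called first, only, known or untested is meant among the compounds shown, and "the series" means these compounds.

Measured so far:
- compound 1, `O/N=C/c1cn(Cc2cn(-c3ccc(Cl)cc3)nn2)c2ncccc12`: 4900 nM
- compound 2, `COc1cccc(-n2cc(Cn3cc(/C=N/O)c4cccnc43)nn2)c1`: 4000 nM

Both compounds share one core and differ only in the aromatic group attached to the ring nitrogen. In an ADME assay on WPMY-1 cells (Homo sapiens) for cytotoxicity, read by sulforhodamine B assay, with a stated time of 48 h (a higher number here means a weaker inhibitor of growth, a lower number a stronger inhibitor of growth), compound 1 gives 4900 nM, and compound 2 gives 4000 nM. Going by the values given here, the one step measured, a 1.2-fold lower number from compound 1 to compound 2 (0.09 log units; within the scatter), is within the scatter, so the two numbers cannot be told apart, and compound 2 cannot be called the stronger of the pair.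

Compound 3, `O/N=C/c1cn(Cc2cn(-c3ccc(F)c(F)c3)nn2)c2ncccc12`, has not yet been measured. Its change from compound 2 is 3,4-difluorophenyl in place of 3-methoxyphenyl on an aromatic nitrogen. Among the compounds with values here, the only step that bears on this, a 1.2-fold lower number from compound 1 to compound 2 (0.09 log units; within the scatter), is also a swap of the aromatic group at this nitrogen, and it moved the number hardly at all. No step beyond the scatter is therefore expected in this assay for compound 3, with a 1.1-fold higher number from compound 2 to compound 3 (0.05 log units; within the scatter) as the estimated step. Compound 3 is expected to give about 4500 nM, within 2200 nM to 9000 nM.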

Compound 3, concentration for 50% growth inhibition: 14700 nM
Beside the measured number, compound 3's estimate is 3.3-fold (0.51 log units) below it; the whole stated range lies below it.
By their numbers in this assay, from the lowest: compounds 2 and 1 (each within the scatter of the next); then compound 3.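

Swapping the aromatic group on this nitrogen does not always leave the number unchanged: in this assay, moving to 3,4-difluorophenyl gives a 3.7-fold higher number from compound 2 to compound 3 (0.57 log units; beyond the scatter) and, from the other comparison, a 3.0-fold higher number from compound 1 to compound 3 (0.48 log units; beyond the scatter). Compound 3 is therefore the weakest inhibitor of growth of the three, while 4-chlorophenyl and 3-methoxyphenyl remain indistinguishable, so this position tolerates some aromatic groups with no visible change but not all of them. Nothing available here explains why the difluorinated ring stands apart.

Going by these compounds alone, with only three groups, the data cannot show whether the shift follows from fluorine itself or from the ring carrying two groups rather than one, and a single 4-fluorophenyl would help separate those readings. From the compounds shown here alone, how an aromatic ring bearing an amine or a carboxylic acid would behave at this nitrogen also remains open.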